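From Methoxyphenyl Ester to Phenylethenyl Ester

The compounds below may be only part of what the source reports. "The series", "measured", "known", "first", "only" and "open" are said of these compounds alone.

For the measured compounds named here, compound 1 `COc1ccc(C(=O)OC2(C(=O)Nc3ccc([N+](=O)[O-])cc3)CCCCC2)cc1` gives 40 nM in an ADME assay on WI-38 cells (Homo sapiens) for inhibition, read by MTT assay, with a stated time of 72 h (a higher number here means a weaker inhibitor, a lower number a stronger inhibitor), the lowest of the two numbers known so far. Compound 2 `CCOC(=O)c1ccccc1C(=O)OC1(C(=O)Nc2ccc([N+](=O)[O-])cc2)CCCCC1` gives 386 nM in this assay, and the gap between these two values lies beyond the scatter. Compound 3 `O=C(/C=C/c1ccccc1)OC1(C(=O)Nc2ccc([N+](=O)[O-])cc2)CCCCC1` carries 2-phenylethenyl in place of 4-methoxyphenyl on a carbonyl carbon. Going by the values given here, no measured pair shows this exact change, so nothing firm anchors its size or direction; a step no larger than the scatter is expected, with the weaker side somewhat more likely. Compound 3 is therefore expected at 80 nM, within 20 nM to 400 nM, an expected step of a 2.0-fold higher number from compound 1 to compound 3 (0.30 log units; within the scatter).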

Compound 3, half-maximal inhibitory concentration: 41 nM
The estimate for compound 3 lay 2.0-fold (0.29 log units) above the measured number; the measured number falls inside the stated range.
By their numbers in this assay, from the lowest: compounds 1 and 3 (each within the scatter of the next); then compound 2.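

In this assay, 2-phenylethenyl in place of 4-methoxyphenyl on a carbonyl carbon gives a 1.0-fold higher number from compound 1 to compound 3 (0.01 log units; within the scatter). This position therefore tolerates two different groups: the oxygen of 4-methoxyphenyl is absent from compound 3, and a double bond outside the aromatic ring is present, yet the two numbers cannot be told apart. No available evidence explains why these two groups match. Still open, going by these compounds, is how this position responds to a group with no aromatic ring, such as a plain alkyl chain, or to a carboxylic acid or an amine.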